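The source may hold more compounds than are shown below. What is called first, only, known or untested is meant among the compounds shown, and "the series" means these compounds.

Compound 3 `C=CC(=O)Nc1cc(Nc2ncc(C#N)c(-c3cn(C)c4ccc(F)cc34)n2)c(OC)cc1N(C)CCN(C)C` is tested in a functional assay on NCI-H1975 cells (Homo sapiens) for antiproliferative activity, read by MTT assay, with a stated time of 72 h (a higher number here means a weaker inhibitor, a lower number a stronger inhibitor), where it gives 11400 nM. That is the highest of the three numbers in hand. Compound 2 `C=CC(=O)Nc1cc(Nc2nccc(-c3cn(C)c4ccc(F)cc34)n2)c(OC)cc1N(C)CCN(C)C` gives 254 nM, and compound 1 `COc1cc(N(C)CCN(C)C)c(NC(=O)/C=C\C(C)C)cc1Nc1ncc(C#N)c(-c2cn(C)c3ccccc23)n1` gives 1110 nM. The one single-point step among these is a 45-fold higher number from compound 2 to compound 3 (1.65 log units; beyond the scatter).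

Compound 4 `CCC/C=C\C(=O)Nc1cc(Nc2ncc(C#N)c(-c3cn(C)c4ccc(F)cc34)n2)c(OC)cc1N(C)CCN(C)C` differs from compound 3 by pent-1-en-1-yl in place of vinyl on a carbonyl carbon. Going by the values given here, no measured pair differs at that position alone, so no step bears on it directly. Compound 1 also carries a chain on that carbonyl carbon, but it differs from compound 3 in more than one place, so its number and that of compound 3 show only that both lie well above compound 2. On this basis the step from compound 3 to compound 4 in this assay is expected to be modest, a 1.4-fold higher number from compound 3 to compound 4 (0.15 log units; within the scatter), if anything towards a higher number. Compound 4 is therefore estimated at 16000 nM, within a range from 4000 nM to 60000 nM.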

Compound 4, half-maximal inhibitory concentration: 2420 nM
Compound 4: the middle estimate sits 6.6-fold (0.82 log units) above what was measured; measured number outside the range, below it.
By their numbers in this assay, from the lowest: compound 2; then compound 1; then compound 4; then compound 3.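

In this assay, putting pent-1-en-1-yl in place of vinyl on the carbonyl carbon gives a 4.7-fold lower number from compound 3 to compound 4 (0.67 log units; beyond the scatter). Going by these compounds alone, this is the first direct reading at this position: the only earlier step concerned a different site, the aromatic carbon where cyano replaces hydrogen, so it could not show that the group on the carbonyl carbon matters or that a chain of this length can lower the number. Nothing measured here explains why the longer chain gives the lower number.

As far as these compounds go, it remains open whether a still longer chain, or a chain ending in an amine, would lower the number further. From the compounds shown here alone, it is also open whether this change would give a step of similar size on a core with hydrogen in place of the cyano group.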